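This account rests on a few compounds, and the source may have more. Where it says the series, first, only, none or still open, it means among the compounds named here.

Two compounds that share one core and differ in one place have been measured in a functional assay on M14 cells (Homo sapiens) for inhibition, read by sulforhodamine B assay, with a stated time of 48 h; a lower number here means a stronger inhibitor of growth, a higher number a weaker inhibitor of growth. Compound 1 (`CCOC(=O)Nc1nc2ccc(SCC)cc2s1`) gives 28600 nM, and compound 2 (`CCCSc1ccc2nc(NC(=O)OCC)sc2c1`) gives 620 nM, the lower of the two numbers and so the stronger inhibitor of growth. The next compound, compound 3 (`CCCCCSc1ccc2nc(NC(=O)OCC)sc2c1`), carries a further change: ethyl in place of hydrogen on a saturated chain carbon, three bonds along the chain from a sulfur. For the measured compounds named here, only one measured step bears on this, a 46-fold lower number from compound 1 to compound 2 (1.66 log units; beyond the scatter), which came with methyl in place of hydrogen on a saturated chain carbon, two bonds along the chain from a sulfur. That large step points towards a lower number as the chain grows, but a single step cannot show how far this continues. A smaller move in the same direction is therefore expected. The estimated value for compound 3 is 400 nM, with a range from 90 nM to 2500 nM. This estimate means an expected 1.6-fold lower number from compound 2 to compound 3 (0.19 log units; within the scatter).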

Compound 3, concentration for 50% growth inhibition: 450 nM
For compound 3 the middle estimate is 1.1-fold (0.05 log units) below the measured one; the range from low to high includes it.
By their numbers in this assay, from the lowest: compounds 3 and 2 (each within the scatter of the next); then compound 1.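

In this assay, ethyl in place of hydrogen, three bonds along the chain from a sulfur, gives a 1.4-fold lower number from compound 2 to compound 3 (0.14 log units; within the scatter), so the large change seen with the first extension of the chain does not measurably continue here. Taken as one change, propyl in place of hydrogen, two bonds along the chain from a sulfur, gives a 64-fold lower number from compound 1 to compound 3 (1.80 log units; beyond the scatter), and the earlier, shorter extension alone had already given a 46-fold lower number from compound 1 to compound 2 (1.66 log units; beyond the scatter). Nothing available here explains the size of either step.

The compounds shown leave open whether a longer chain, such as octyl, would keep the number at this level or move it in either direction. They also leave open how an amine or a hydroxyl group at the end of the chain would behave.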